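The source may hold more compounds than are shown below. What is called first, only, known or untested is meant among the compounds shown, and "the series" means these compounds.

Measured so far in a functional assay on MDA-MB-231 cells (Homo sapiens) for inhibition; on this read-out higher numbers stand for weaker inhibition and lower numbers for stronger inhibition:
compound 1 `O=C(NO)c1ccc(-c2ccc(CNc3ccccc3)cn2)s1` gives 630 nM;
compound 2 `O=C(NO)c1ccc(-c2ccccn2)s1` gives 11000 nM;
compound 3 `CN(Cc1ccccc1)Cc1ccc(-c2ccc(C(=O)NO)s2)nc1` gives 370 nM.

Compound 1 sits second highest of the three numbers. Its nearest neighbour is compound 3, whose number is lower but within the usual scatter, so the two cannot be ranked against each other. Compound 2, which carries the shared core without any aminomethyl arm, lies far above both, beyond the scatter; the gap between compound 2 and compound 1 is the only difference in this small set that stands clear of noise. Among the measured compounds shown here, no single-change step between measured compounds is available, so the size of any substituent effect on the amine nitrogen has not been measured directly.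

Compound 4 `O=C(NO)c1ccc(-c2ccc(CNCc3ccc(Cl)cc3)cn2)s1` has not yet been measured. It differs from compound 1 as follows: 4-chlorobenzyl in place of phenyl on an amine nitrogen. Compound 3, the other measured compound with a benzyl group on the amine nitrogen, gives 370 nM, which is the lowest number seen here. On that basis compound 4 is expected to land close to compound 1 and compound 3, with a step from compound 1 that is small and, if anything, toward a lower number, most likely not beyond the scatter: a 1.6-fold lower number from compound 1 to compound 4 (0.20 log units; within the scatter). The estimate for compound 4 in this assay is 400 nM, with a range from 150 nM to 1200 nM.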

Compound 4, half-maximal inhibitory concentration: 300 nM
Estimate against measurement, compound 4: 1.3-fold (0.12 log units) above; the range from low to high includes it.
By their numbers in this assay, from the lowest: compounds 4, 3 and 1 (each within the scatter of the next, the first and the last beyond it); then compound 2.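

In this assay, among the compounds shown here, the change of 4-chlorobenzyl in place of phenyl on an amine nitrogen gives the first directly measured single-change step at this position: a 2.1-fold lower number from compound 1 to compound 4 (0.32 log units; beyond the scatter). The step is modest but beyond the scatter, so this position responds to the group it carries, and the bulkier 4-chlorobenzyl, with its larger heavy-atom count, costs nothing in inhibition here. Nothing available bears on why the number moves, so the step stands as an observation only.

The change swaps phenyl for a group that differs in both the chain carbon and the chlorine, so this one step cannot divide its size between the two, and compound 3 differs from compound 4 in more than one place and cannot settle the matter. Still open, as far as these compounds go, is how the read-out responds on this nitrogen to a 4-methoxybenzyl group, a longer chain such as 2-phenylethyl, or a saturated ring amine such as morpholine in place of the aminomethyl arm.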